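The source may report more compounds than this note shows. Statements on the series, on what has been measured and on what is new or still open speak of the compounds shown alone.

Measured in an assay on isolated protein for inhibition of aldehyde dehydrogenase 1A1 (Homo sapiens), read by spectrophotometry, tested at 10 uM; a lower number here means less inhibition, a higher number more inhibition at the concentration tested (going by the name of the read-out):
compound 1 `Cc1cccc(Cn2c(CN3CCN(C(=O)C4CCCC4)CC3)nc3ccccc32)c1`: 67.5%
compound 2 `COc1cccc(Cn2c(CN3CCN(C(=O)C4CC4)CC3)nc3ccccc32)c1`: 44.4%
compound 3 `O=C(C1CC1)N1CCN(Cc2nc3ccccc3n2Cc2ccccc2)CC1`: 23.9%

Compound 3 stands lowest of the three. Among the measured compounds shown here, the nearest number comes from the single step of a number 20.5 percentage points lower from compound 2 to compound 3 (beyond the scatter), while compound 1 sits further above it; compound 1 differs from compound 3 in two places, so no single step joins them. Compound 4 `O=C(C1CC1)N1CCN(Cc2nc3ccccc3n2Cc2cccc(Cl)c2)CC1` differs from compound 3 by chloro in place of hydrogen on an aromatic carbon. For the measured compounds named here, the only step that bears on this change is the removal of a methoxy group, which lowered inhibition in this assay by a number 20.5 percentage points lower from compound 2 to compound 3 (beyond the scatter); a chloro entering where a hydrogen stood is expected to move the number back upward, by about a number 18.1 percentage points higher from compound 3 to compound 4 (beyond the scatter). Compound 4 is therefore estimated at 42%, with a range from 22% to 62%.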

Compound 4, a percentage reported as inhibition, at one concentration (the size of the read-out at that concentration, not a potency): 71.6%
Compound 4: middle estimate off by 29.6 percentage points, on the low side, and the stated range ends below it.
By their numbers in this assay, from the lowest: compound 3; then compound 2; then compounds 1 and 4 (each within the scatter of the next).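

In this assay, the change from benzyl to 3-chlorobenzyl gives a number 47.7 percentage points higher from compound 3 to compound 4 (beyond the scatter) and is a large step, so this place on the ring can carry far more inhibition than the methoxy step alone showed. Chloro in place of methoxy gives a number 27.2 percentage points higher from compound 2 to compound 4 (beyond the scatter) and thus shows that the two groups are not interchangeable at this place. Nothing available explains the size of either step. From the compounds shown here alone, whether bromo or trifluoromethyl at this place would match chloro remains open, as does whether the gain from chloro carries over to compounds with a cyclopentyl amide.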